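Swapping the Aryl Group on the Ring Nitrogen

The source may report more compounds than this note shows. Statements on the series, on what has been measured and on what is new or still open speak of the compounds shown alone.

Of the compounds shown here, two have so far been measured in a functional assay on PC-12 cells (Rattus norvegicus) for cytotoxicity, read by MTT assay, with stated times of 2 h and 24 h, tested at 10 uM; a lower number here means a weaker effect, a higher number a stronger effect of the compound at the concentration tested. Compound 1 `Cc1ccc(-n2nc(-c3ccc(C(F)(F)F)cc3O)nc2-c2ccccc2O)c(C)c1` gives 106% in this assay. Compound 2 `Oc1cc(C(F)(F)F)ccc1-c1nc(-c2ccccc2O)n(-c2ccc(Cl)cc2Cl)n1`, which carries a 2,4-dichlorophenyl group in place of the 2,4-dimethylphenyl group on an aromatic nitrogen, gives 95.2% in this assay. That exchange brought a number 10.8 percentage points lower from compound 1 to compound 2 (beyond the scatter), so compound 2 stands as the lower of the two numbers, with compound 1 above it.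

Compound 3 `Oc1cc(C(F)(F)F)ccc1-c1nc(-c2ccccc2O)n(-c2cc(F)cc(F)c2)n1` has not yet been measured. It differs from compound 2 in one place: 3,5-difluorophenyl in place of 2,4-dichlorophenyl on an aromatic nitrogen. Within the data shown here, the only measured step at this position is a number 10.8 percentage points lower from compound 1 to compound 2 (beyond the scatter), a modest one. Among the measured compounds shown here, no compound carrying a 3,5-difluorophenyl group has been measured, so the expectation rests on that single modest step alone. Another exchange of the group on the aromatic nitrogen is therefore expected to change the number little, if at all. For compound 3 the step is estimated at a number 1.2 percentage points lower from compound 2 to compound 3 (within the scatter), which lies within the usual scatter. Compound 3 is thus expected to give about 94% in this assay, with a likely range from 80% to 108%.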

Compound 3, a percentage reported as activity, at one concentration (the size of the read-out at that concentration, not a potency): 106%
Compound 3: the middle estimate sits 12 percentage points below what was measured; the range from low to high includes it.
By their numbers in this assay, from the lowest: compound 2; then compounds 1 and 3 (each within the scatter of the next).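

In this assay the exchange on the aromatic nitrogen can move the number up as well as down: going to the 3,5-difluorophenyl group brought a number 10.8 percentage points higher from compound 2 to compound 3 (beyond the scatter) and so reversed the size of the earlier step. Set against the 2,4-dimethylphenyl group, the same 3,5-difluorophenyl group brought no change at the digits printed from compound 1 to compound 3 (within the scatter) and therefore leaves these two groups, which differ in their atoms and their pattern on the ring, indistinguishable here. Compound 2, with its 2,4-dichlorophenyl group, is thus the one that stands apart, lowest of the three, though only by modest steps. Nothing measured here offers an explanation for that difference.

Compound 2 and compound 3 differ both in the halogen and in the pattern of its placement on the phenyl ring, so the compounds shown cannot say which of these two changes carries the step. They also leave open how the number would respond to a plain phenyl group, to a phenyl ring carrying an amine or a carboxylic acid, or to a longer alkyl chain on that nitrogen in place of an aryl group.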